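The compounds below may be only part of what the source reports. "The series", "measured", "known", "first", "only" and "open" are said of these compounds alone.

Compound 2, `CCOc1ccccc1-c1ncc(C(=O)O)c(=O)[nH]1`, is the reference point of the series. In a functional assay on the whole organism (strain Sprague-Dawley) for inhibition, with Rattus norvegicus as the target, with a stated time of 10 min (on this read-out lower numbers stand for an effect already at smaller amounts and higher numbers for an effect only at larger amounts of compound), compound 2 gives 0.5 mg/kg, the lowest of the two numbers in hand; compound 3, `CCCOc1ccccc1-c1ncc(C(=O)O)c(=O)[nH]1`, gives 0.9 mg/kg, and a 1.8-fold higher number from compound 2 to compound 3 (0.26 log units; within the scatter), so the two values are not separated. Compound 1, `O=C(O)c1cnc(-c2ccccc2[N+](=O)[O-])[nH]c1=O`, carries a nitro group where compound 2 carries an ethoxy group. In this assay compound 1 gives > 50 mg/kg, which is a limit of the assay and not a number, (the limit of > 50 mg/kg in this assay, at which 1 of the 3 values shown sits).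

Compound 4, `O=C(O)c1cnc(-c2ccccc2OCC2CC2)[nH]c1=O`, is not yet measured in this assay. Relative to compound 2 it differs by cyclopropyl in place of methyl on a saturated chain carbon bound to an oxygen on an aromatic ring. Within the data shown here, the only measured step that touches the same chain is the one between compound 2 and compound 3, a 1.8-fold higher number from compound 2 to compound 3 (0.26 log units; within the scatter), which shows that lengthening the chain by one carbon leaves the value where it was. The larger steps, an at least 100-fold lower number from compound 1 to compound 2 (2.00 log units; beyond the scatter) and an at least 55-fold lower number from compound 1 to compound 3 (1.74 log units; beyond the scatter), concern the exchange of nitro for an alkoxy group and do not bear on the size of the alkyl part. Extending the chain with a cyclopropyl is therefore expected to give a step of about a 2.0-fold higher number from compound 2 to compound 4 (0.30 log units; within the scatter), not beyond the scatter, in this assay. For compound 4 the expected value is 1 mg/kg, within a range of 0.4 mg/kg to 3 mg/kg.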

Compound 4, dose for 50% inhibition: 0.1 mg/kg
Compound 4: middle estimate off by 10-fold (1.00 log units), on the high side; measured number below the stated range.
By their numbers in this assay, from the lowest: compound 4; then compounds 2 and 3 (each within the scatter of the next). At a limit, above all of these: compound 1.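

In this assay, the group on the saturated chain carbon bound to an oxygen on an aromatic ring now separates the values: cyclopropyl in place of methyl gives a 5.0-fold lower number from compound 2 to compound 4 (0.70 log units; beyond the scatter), and cyclopropyl in place of ethyl gives a 9.0-fold lower number from compound 3 to compound 4 (0.95 log units; beyond the scatter). The ethoxy of compound 2 and the propoxy of compound 3 stay within the scatter of each other, so among these compounds the clear change goes with the cyclopropyl group and not with chain length alone. The step from the nitro compound also grows to an at least 500-fold lower number from compound 1 to compound 4 (2.69 log units; beyond the scatter), but it is read against a value for compound 1 that is a limit of the assay and not a number: the limit of > 50 mg/kg in this assay, at which 1 of the 4 values shown sits.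

Still open, as far as these compounds go, is whether the change belongs to the three-membered ring itself or to branching at that carbon, a question that isopropyl, cyclobutyl or a longer chain such as butyl on the same oxygen would address. Also open, from the compounds shown here alone, is how an amine or a fluorine on the cyclopropylmethoxy group would read in this assay.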